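Dimethylamino in place of pyrrolidinyl on the shared core

The source may hold more compounds than are shown below. What is called first, only, known or untested is meant among the compounds shown, and "the series" means these compounds.

Measured compounds:
Compound 1, `CSc1ccccc1Nc1nc2c(Nc3ccc(C(F)(F)F)cc3)ncnc2s1`, in a functional assay on HEK293 cells for antagonist activity at transient receptor potential cation channel subfamily V member 1 (Homo sapiens), read by calcium flux; on this read-out higher numbers stand for weaker inhibition and lower numbers for stronger inhibition: 43 nM.
Compound 2, `O=C(O)c1ccc(Nc2ncnc3sc(Nc4c(Cl)cccc4Cl)nc23)cc1`, in this assay gives only a limit of the assay: > 5000 nM.
Compound 3, `FC(F)(F)c1ccc(Nc2nc(N3CCCC3)nc3sc(Nc4c(Cl)cccc4Cl)nc23)cc1`, in this assay: 12 nM.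

Compound 3 holds the lowest of the two numbers; compound 1 sits at a higher number, a gap beyond the usual scatter. The third value is a limit (the limit of > 5000 nM in this assay, at which 1 of the 3 values shown sits). Compound 4, `CN(C)c1nc(Nc2ccc(C(F)(F)F)cc2)c2nc(Nc3c(Cl)cccc3Cl)sc2n1`, differs from compound 3 by dimethylamino in place of pyrrolidin-1-yl on an aromatic carbon, on an aromatic carbon between two ring nitrogen atoms. Among the compounds with values here, no pair of measured compounds differs in one place only, so no measured step guides the expectation. The step from compound 3 to compound 4 is expected to be a 1.8-fold higher number from compound 3 to compound 4 (0.26 log units; within the scatter), within the scatter or a slight weakening. Compound 4 is estimated at 22 nM, within 7 nM to 70 nM.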

Compound 4, half-maximal inhibitory concentration: 59 nM
Compound 4: the middle estimate sits 2.7-fold (0.43 log units) below what was measured, and the stated range covers the measured number.
By their numbers in this assay, from the lowest: compound 3; then compounds 1 and 4 (each within the scatter of the next). At a limit, above all of these: compound 2.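

In this assay, the exchange of pyrrolidin-1-yl for dimethylamino on the aromatic carbon between two ring nitrogen atoms gives a 4.9-fold higher number from compound 3 to compound 4 (0.69 log units; beyond the scatter). Within the data shown here, this is the first single-place comparison, and it shows that the read-out responds to the amino group at this position, with the ring-closed pyrrolidin-1-yl giving the lower number. Nothing measured here accounts for the size of this step. As far as these compounds go, it remains open how piperidin-1-yl, morpholin-4-yl or diethylamino would read at this carbon, and whether the same exchange would give a similar step with other groups elsewhere on the shared core.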